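Cytotoxicity notes on a small thiocarbonyl series

This account rests on a few compounds, and the source may have more. Where it says the series, first, only, none or still open, it means among the compounds named here.

Measured compounds:
compound 1, `FC(F)(F)c1cccc(NC(=S)Nc2ccc(I)cc2)c1`: 9500 nM
compound 2, `Fc1ccc(NC(=S)Nc2cccc(C(F)(F)F)c2)cc1Cl`: 11000 nM
compound 3, `O=C(NC(=S)Nc1cccc(C(F)(F)F)c1)[C@H]1C[C@@H]2CC[C@H]1C2`: 10000 nM

In an ADME assay on MDBK cells (Bos taurus) for cytotoxicity, read by MTT assay, with a stated time of 96 h (a lower number here means that less compound is tolerated, a higher number that more compound is tolerated), compound 1 gives 9500 nM, the lowest of the three numbers; compound 3 with 10000 nM and compound 2 with 11000 nM both sit within the scatter of it, so the three are not distinguishable by this assay. Among the compounds with values here, no pairwise step between measured compounds is available, and the three structures differ from one another in more than one place.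

Compound 4, `Fc1cccc(NC(=S)Nc2cccc(C(F)(F)F)c2)c1`, has not been measured. It differs from compound 1 by 3-fluorophenyl in place of 4-iodophenyl on an amide-type nitrogen. Within the data shown here, the measured set gives no single-change comparison to rest on; it shows only that changes on this nitrogen, including the bridged bicyclic amide of compound 3 and the halogenated aryl of compound 2, leave the number where compound 1 stands. The step from compound 1 to compound 4 in this assay is therefore expected to be none beyond the scatter, a 1.1-fold higher number from compound 1 to compound 4 (0.04 log units; within the scatter). For compound 4 the estimate is 10500 nM, with a range of 4500 nM to 25000 nM.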

Compound 4, half-maximal cytotoxic concentration: 10000 nM
Compound 4: middle estimate off by 1.1-fold (0.02 log units), on the high side; the measured number falls inside the stated range.
By their numbers in this assay, from the lowest: compounds 1, 3, 4 and 2 (each within the scatter of the next).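

In this assay, the series now has its first comparison at a single place: 3-fluorophenyl in place of 4-iodophenyl on an amide-type nitrogen gives a 1.1-fold higher number from compound 1 to compound 4 (0.02 log units; within the scatter), within the scatter. With the rest of compound 1 held constant, this exchange of both the halogen and its printed ring location does not separate the two compounds in this read-out. No available measurement bears on the reason for this result.

As far as these compounds go, whether a phenyl ring carrying an amine or a carboxylic acid at this place would stay within the scatter of compound 1 remains open. Trifluoromethyl is common to all four compounds, so the outcome of replacing it with a nitrile is also open.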